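The source may hold more compounds than are shown below. What is called first, only, known or untested is meant among the compounds shown, and "the series" means these compounds.

Measured so far:
Compound 1, `O=C1OC(c2ccc([N+](=O)[O-])cc2)=N/C1=C\c1ccncc1`, gives 0%.
Compound 2, `O=C1OC(c2cccc(Br)c2)=N/C1=C\c1ccncc1`, gives 1%.

Both numbers come from an assay on isolated protein for inhibition of Death-associated protein kinase 3 (Homo sapiens), tested at 1 uM; a lower number here means a weaker effect, a higher number a stronger effect of the compound at the concentration tested. Compound 2 and compound 1 lie within the scatter of each other, and both show essentially no inhibition at the concentration tested. Compound 3, `O=C1OC(c2ccccc2)=N/C1=C\c1ccncc1`, has not yet been measured. It differs from compound 2 in one place: hydrogen in place of bromo on an aromatic carbon. The measured pair offers no guide to this particular change, since compound 1 and compound 2 differ from each other in a different group and still give the same kind of result. Because compound 2 gives 1% and compound 1 gives 0%, no step beyond the scatter is expected in this assay, in either direction. The expected step is no change at the digits printed from compound 2 to compound 3 (within the scatter), which is no change beyond the scatter. Compound 3 is therefore estimated to give 1%, with a range from -5% to 8%.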

Compound 3, a percentage reported as inhibition, at one concentration (the size of the read-out at that concentration, not a potency): 0%
For compound 3 the middle estimate is 1 percentage points above the measured one, within the range that was stated.
By their numbers in this assay, from the lowest: compounds 1, 3 and 2 (each within the scatter of the next).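

In this assay, hydrogen in place of bromo on an aromatic carbon, meta to a large group, gives a number 1 percentage points lower from compound 2 to compound 3 (within the scatter), and hydrogen in place of nitro gives no change at the digits printed from compound 1 to compound 3 (within the scatter). Compound 3 therefore adds a reference point with neither group on the ring, and with only hydrogen there, the read-out remains close to nothing, so neither bromo nor nitro can be seen to add to or take away from inhibition at this concentration. Nothing available explains why all three compounds sit so close to nothing.

Going by these compounds, whether an amine, a carboxylic acid or a methoxy group on this ring would give a clear read-out remains open. With all three values this close to nothing, it is also unknown whether this ring matters at all, or whether changes elsewhere on the shared core would matter more.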